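This account rests on a few compounds, and the source may have more. Where it says the series, first, only, none or still open, it means among the compounds named here.

Compound 1, `C[C@H](Oc1cc2cc(C(N)=O)ccc2nc1N)c1cc(F)c(F)cc1-n1cccn1`: 14 uL/min
Compound 2, `C[C@H](Oc1cc2cc(F)ccc2nc1N)c1cc(C(=O)O)ccc1-n1cccn1`: 4 uL/min
Compound 3, `C[C@H](Oc1cc2cc(C(N)=O)ccc2nc1N)c1ncc(F)cc1-n1cccn1`: < 2 uL/min

In an ADME assay on cells (Hepatocyte, Homo sapiens) for metabolic stability (a lower number here means slower removal, a higher number faster removal of the compound), compound 2 gives 4 uL/min, the lowest of the two numbers reported. Compound 1 gives 14 uL/min in this assay, a higher number, beyond the usual scatter. For compound 3 the result is a limit of the assay, (the limit of < 2 uL/min in this assay, at which 1 of the 3 values shown sits), and not a number. Compound 4, `C[C@H](Oc1cc2cc(F)cc(F)c2nc1N)c1cc(C(=O)O)ccc1-n1cccn1`, has not yet been measured in this assay. It differs from compound 2 by fluoro in place of hydrogen on an aromatic carbon. Among the compounds with values here, no pair measured here differs in only one place, so no measured step guides the expectation. A small change, within the scatter, is expected as the step of a 1.1-fold lower number from compound 2 to compound 4 (0.06 log units; within the scatter). Compound 4 is therefore estimated to give 3.5 uL/min in this assay, within a range from 2 uL/min to 7 uL/min.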

Compound 4, intrinsic clearance in a liver preparation (reported as CLH), per the amount of preparation that the assay uses in the Hepatocyte assay: < 3 uL/min
Compound 4 ended at the assay's limit (the forecaster's own chance of this, stated with the estimate: 25%); middle value at least 1.1-fold (0.06 log units) from the limit.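

The result for compound 4 is a limit of the assay and not a number: the limit of < 3 uL/min in the Hepatocyte assay, at which 1 of the 4 values shown sits.

In the Hepatocyte assay the change reads as an at least 1.3-fold lower number from compound 2 to compound 4 (0.12 log units; that floor lies within the scatter), so fluoro in place of hydrogen on this aromatic carbon, ortho to a fused ring, shows no sign of faster removal. In a physicochemical assay for lipophilicity, using the shake flask method (on this read-out higher numbers stand for higher lipophilicity and lower numbers for lower lipophilicity), compound 2 gives 0.9 and compound 4 gives 1, values within the usual scatter of each other.

As far as these compounds go, the true clearance of compound 4 remains open. So does whether chloro, methoxy or an amine on this carbon would give the same result.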